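Adding a Second Chloro Group to Compound 3

A few compounds are considered here, and "the series" means these few. Any claim that something is new, unique, unknown or untested is made for them only; others in the source may bear on it.

Three compounds share one core and differ only in the group attached to one aromatic carbon. Compound 1 `CCc1ccccc1NC(=O)N[C@@H](C)c1ccccc1` carries an ethyl group; in an ADME assay on the whole organism with Oryza sativa as the target, tested at 1 uM (on this read-out lower numbers stand for a stronger effect and higher numbers for a weaker effect at the one concentration tested), compound 1 gives 100%. Compound 2 `C[C@H](NC(=O)Nc1ccccc1C(C)(C)C)c1ccccc1` carries a tert-butyl group, and compound 2 gives 99%. Compound 3 `C[C@H](NC(=O)Nc1ccccc1Cl)c1ccccc1` carries a chloro group, and compound 3 gives 104%. Compound 3 stands at the highest of the three numbers, yet a number 4 percentage points higher from compound 1 to compound 3 (within the scatter) and a number 5 percentage points higher from compound 2 to compound 3 (within the scatter) are both within the scatter, as is a number 1 percentage points lower from compound 1 to compound 2 (within the scatter). All three compounds therefore show the same weak effect at the one concentration tested.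

Compound 4 `C[C@H](NC(=O)Nc1c(Cl)cccc1Cl)c1ccccc1` is the next step: chloro in place of hydrogen on an aromatic carbon. For the measured compounds named here, no measured step adds a group where only a hydrogen stood; the three measured steps swap one group for another, and none of them moved the read-out beyond the scatter. Going by the values given here, those steps are the only guide, and they give no sign that a further change at an aromatic carbon shifts the number. The step from compound 3 to compound 4 is therefore expected to be a number 4 percentage points lower from compound 3 to compound 4 (within the scatter), nothing beyond the scatter. Compound 4 is estimated to give 100% in this assay, between 86% and 112%.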

Compound 4, a percentage reported as activity, at one concentration (the size of the read-out at that concentration, not a potency): 99%
Compound 4: the middle estimate sits 1 percentage points above what was measured; low and high end bracket the measured number.
By their numbers in this assay, from the lowest: compounds 2, 4, 1 and 3 (each within the scatter of the next).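

This is the first step shown that adds a group where only a hydrogen stood, rather than swapping one group for another, and in this assay it gives a number 5 percentage points lower from compound 3 to compound 4 (within the scatter). The new chloro group sits on an aromatic carbon, ortho to a large group and meta to a chloro group, so this position can carry a chloro group in place of hydrogen with no shift beyond the usual scatter, just as the earlier swaps of ethyl, tert-butyl and chloro on the ring produced none. No measurement here bears on why the read-out stays put after this addition.

As far as these compounds go, whether a group other than chloro at this same position, such as an amine, a methoxy group or a carboxylic acid, would move the number remains open. Also open, from the compounds shown here alone, is whether a change elsewhere on the shared core, such as a longer chain in place of the methyl group on the carbon carrying the unsubstituted phenyl ring, would give a read-out clearly apart from that of compound 3.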